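The source may report more compounds than this note shows. Statements on the series, on what has been measured and on what is new or still open speak of the compounds shown alone.

Compound 1 `Nc1scc(CN2CCN(c3cccnc3)CC2)c1C(=O)c1ccc(Cl)cc1`: 3.4%
Compound 2 `Nc1scc(CN2CCN(c3c(F)cccc3F)CC2)c1C(=O)c1cccc(C(F)(F)F)c1`: 1.3%

In a functional assay on CHO cells with adenosine receptor A1 (Homo sapiens) as the target, read by cAMP accumulation and immunoassay, with a stated time of 6 min, tested at 0.1 uM (on this read-out higher numbers stand for a weaker effect at the one concentration tested and lower numbers for a stronger effect), compound 1 stands at the top of the two numbers shown, but its gap to compound 2 lies within the scatter, so the two cannot be told apart. Compound 3 `Nc1scc(CN2CCN(c3cccc(Cl)c3)CC2)c1C(=O)c1ccc(Cl)cc1` is not yet measured. It differs from compound 1 in one place: 3-chlorophenyl in place of pyridin-3-yl on an amine nitrogen in a ring. Among the measured compounds shown here, no step between measured compounds covers a change of this kind, and both measured numbers sit at the low end of the read-out. From this change no step beyond the scatter is expected in this assay. Compound 3 is expected to give about 4% in this assay, between 0% and 12%. The expected step of a number 0.6 percentage points higher from compound 1 to compound 3 (within the scatter) is therefore small.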

Compound 3, a percentage reported as activity, at one concentration (the size of the read-out at that concentration, not a potency): -20%
Estimate against measurement, compound 3: 24 percentage points above, outside the stated range (below it).
By their numbers in this assay, from the lowest: compound 3; then compounds 2 and 1 (each within the scatter of the next).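

In this assay, the group on the amine nitrogen in the six-membered non-aromatic ring with 2 nitrogen can move the number: 3-chlorophenyl in place of pyridin-3-yl gives a number 23.4 percentage points lower from compound 1 to compound 3 (beyond the scatter). Among the compounds shown here, this is the first step beyond the scatter, and it comes from a change at this one place with the rest of compound 1 kept. Nothing measured here explains the step. As far as these compounds go, it remains open whether the step follows the added chlorine or the lost ring nitrogen, and unsubstituted phenyl at this place would separate the two. Also open, from the compounds shown here alone, is how a methoxy group or a carboxylic acid in place of the chlorine would read.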